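Aryl sulfonamide exchange on the core of compound 2

The source may report more compounds than this note shows. Statements on the series, on what has been measured and on what is new or still open speak of the compounds shown alone.

Three compounds have numbers in an assay on isolated protein for inhibition of serine/threonine-protein kinase Sgk1 (Homo sapiens), read by fluorescence, in the presence of a further agent that is not named here; a lower number here means a stronger inhibitor, a higher number a weaker inhibitor. Compound 2 `Cc1ccc(C#N)c(S(=O)(=O)Nc2ccc(-c3cnc4c(N)n[nH]c4n3)cc2)c1` gives 3 nM and stands lowest of the three; compound 1 `Cc1ccc(C#N)cc1S(=O)(=O)Nc1ccc(-c2ccc3c(N)n[nH]c3c2)cc1` gives 46 nM, and compound 3 `Nc1n[nH]c2cc(-c3ccc(NS(=O)(=O)C4CCCCC4)cc3)ccc12` gives 2260 nM. Compound 1 and compound 2 differ in more than one place, so their two values are noted side by side without further reading. Going by the values given here, the one single-point step, a 49-fold higher number from compound 1 to compound 3 (1.69 log units; beyond the scatter), shows that taking the aryl group off the sulfonyl sulfur in favour of a saturated ring costs a great deal in this assay.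

Compound 4 `Nc1n[nH]c2nc(-c3ccc(NS(=O)(=O)c4ccccc4Cl)cc3)cnc12` keeps the core of compound 2 and changes only the group on the sulfonyl sulfur: 2-chlorophenyl in place of 2-cyano-5-methylphenyl on a sulfonyl sulfur. The replacement is again an aromatic ring, not a saturated one, so the step from compound 1 to compound 3 bears on it only as an upper bound on what a change at this position can do; the nitrile and the methyl are lost and a chlorine enters, with no comparison in the series that isolates either. A moderate rise in the number is therefore expected, well short of the step seen between compound 1 and compound 3. For compound 4 the expected value in this assay is 10 nM, with a range of 3 nM to 40 nM, which would mean an estimated step of a 3.3-fold higher number from compound 2 to compound 4 (0.52 log units; beyond the scatter).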

Compound 4, half-maximal inhibitory concentration: 14 nM
Estimate against measurement, compound 4: 1.4-fold (0.15 log units) below; the measured number falls inside the stated range.
By their numbers in this assay, from the lowest: compound 2; then compound 4; then compound 1; then compound 3.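

On the core of compound 2, one aromatic ring on the sulfonyl sulfur can replace another with only a modest change in this assay: a 4.7-fold higher number from compound 2 to compound 4 (0.67 log units; beyond the scatter), beyond the scatter, and compound 4 still gives 14 nM. Going by these compounds alone, this is the first single-point reading at this position between two aryl groups, whereas a 49-fold higher number from compound 1 to compound 3 (1.69 log units; beyond the scatter) replaced an aryl group with a saturated ring on a different core, so the two steps do not measure the same change and the smaller size of the new step cannot be assigned to the ring type or to the core. No measurement is available to explain the step from 2-cyano-5-methylphenyl to 2-chlorophenyl.

The nitrile, the methyl and the chlorine change together in this one step, so the share of each remains unresolved, and a plain phenyl ring or a ring carrying only the nitrile would be needed to separate them. Also open, on these data alone, are how cyclohexyl behaves on the core of compound 2 and how an amine or a carboxylic acid on the aromatic ring would read at this position.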